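Urea to amide exchange on the shared core

The source may report more compounds than this note shows. Statements on the series, on what has been measured and on what is new or still open speak of the compounds shown alone.

Compound 2 `COc1cc(Cl)cc(-c2nn(-c3cccc(NC(=O)Nc4ccc(Cl)c(C(F)(F)F)c4)c3)cc2-c2ccncc2)c1` is the lower of the two numbers in a functional assay on DU-145 cells (Homo sapiens) for inhibition, read by sulforhodamine B assay, with a stated time of 48 h, tested at 1 uM; on this read-out higher numbers stand for a weaker effect at the one concentration tested and lower numbers for a stronger effect: compound 2 gives 64%, while compound 1 `O=C(Nc1cccc(-n2cc(-c3ccncc3)c(-c3cc(O)cc(Cl)c3)n2)c1)Nc1ccc(Cl)c(C(F)(F)F)c1` gives 96%, the difference being a number 32 percentage points lower from compound 1 to compound 2 (beyond the scatter). Compound 3 `COc1cc(Cl)cc(-c2nn(-c3cccc(NC(=O)c4cccc(C(F)(F)F)c4)c3)cc2-c2ccncc2)c1` differs from compound 2 by 3-(trifluoromethyl)phenyl in place of (4-chloro-3-(trifluoromethyl)phenyl)amino on a carbonyl carbon. Among the compounds with values here, no measured step touches this carbonyl position, so the one recorded step gives no direct guidance; the expectation rests only on compound 2 and its value 64%. Going by these compounds, a step of a number 12 percentage points higher from compound 2 to compound 3 (beyond the scatter) is expected, since the change is untested. Compound 3 is estimated at 76%, between 52% and 98%.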

Compound 3, a percentage reported as activity, at one concentration (the size of the read-out at that concentration, not a potency): 100%
For compound 3 the middle estimate is 24 percentage points below the measured one; the whole stated range lies below it.
By their numbers in this assay, from the lowest: compound 2; then compounds 1 and 3 (each within the scatter of the next).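

In this assay, the carbonyl position proves sensitive: 3-(trifluoromethyl)phenyl in place of (4-chloro-3-(trifluoromethyl)phenyl)amino gives a number 36 percentage points higher from compound 2 to compound 3 (beyond the scatter), a weaker effect at the one concentration tested. This single change removes both the amino nitrogen and the chlorine, so the step cannot be assigned to either one. No data on hand bear on the reason for this step.

Still open, going by these compounds, is whether either the nitrogen or the chlorine alone accounts for the step. Also open, on these data alone, is how a group such as morpholine would behave on this carbonyl carbon.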